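One added carbon on a compound at the limit

The source may report more compounds than this note shows. Statements on the series, on what has been measured and on what is new or still open speak of the compounds shown alone.

Compound 1 `Cc1ccc2oc(C)c(C(=O)NCc3ccc(N4CCC(c5ccc(OC(F)(F)F)cc5)CC4)cc3)c2c1`: "not determined" (no result reported)
Compound 2 `Cc1cn2c(C(=O)NCc3ccc(N4CCC(c5ccc(OC(F)(F)F)cc5)CC4)cc3)c(C)nc2s1`: > 100000 nM
Compound 3 `Cc1nc2sccn2c1C(=O)NCc1ccc(N2CCC(c3ccc(OC(F)(F)F)cc3)CC2)cc1`: > 100000 nM

These entries come from a toxicity assay on Vero cells (Chlorocebus sabaeus) for cytotoxicity, read by CCK-8 assay, with a stated time of 72 h; on this read-out higher numbers stand for weaker inhibition and lower numbers for stronger inhibition. Compound 3 gives only a limit, > 100000 nM. Compound 2 also gives only a limit, > 100000 nM. Compound 1 offers no result for comparison.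

Compound 4 `Cc1nn2c(C)csc2c1C(=O)NCc1ccc(N2CCC(c3ccc(OC(F)(F)F)cc3)CC2)cc1` differs from compound 3 in a single place, on a carbonyl carbon: a group of 10 heavy atoms (7 carbon, 2 nitrogen, 1 sulfur; 2 five-membered aromatic rings with 2 hetero atoms each) in place of a group of 9 heavy atoms (6 carbon, 2 nitrogen, 1 sulfur; 2 five-membered aromatic rings with 2 hetero atoms each), on a carbonyl carbon. For the measured compounds named here, the one measured step that bears on this change is a step that the two limits leave unreadable from compound 2 to compound 3, which also concerns a methyl on an aromatic carbon. Going by the values given here, its size cannot be read, and the only other evidence is the limit of > 100000 nM in this assay, at which 2 of the 3 values shown sit. No step beyond the scatter is therefore expected in this assay, and a further limit is more likely than a number. The expected step is a number no higher from compound 3 to compound 4 (the limit leaves the size open). This expectation rests on compound 3 and its limit of > 100000 nM. For compound 4 the estimated value is 100000 nM, with an expected range from 50000 nM to 200000 nM.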

Compound 4, half-maximal inhibitory concentration: > 100000 nM
Compound 4: a limit, no number; the forecaster's own chance of this, stated with the estimate: 85%; the middle value sits exactly at the limit.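

In this assay compound 4 gives > 100000 nM, a limit and not a number. The steps linking compound 4 to compound 2 and compound 3 therefore cannot be read. The compounds shown leave open at what concentration any of these three would reach half-maximal inhibition in this assay.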